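A Morpholine Amide in Place of the Oxazolidinone Chain

The source may hold more compounds than are shown below. What is called first, only, known or untested is meant among the compounds shown, and "the series" means these compounds.

Compound 1 `CN1CCN(CCOc2nn(-c3ccccc3F)c3ccc(F)cc23)C1=O` gives 7200 mL/min/kg in an ADME assay on liver for metabolic stability, with Liver microsome (Rattus norvegicus) as the target, using microsomes and NADPH, with a stated time of 30 min, tested at 0.5 uM; a lower number here means slower removal, a higher number faster removal of the compound.
Compound 2 `O=C1OCCN1CCOc1nn(-c2ccccc2F)c2ccc(F)cc12` gives 2480 mL/min/kg in this assay.
Compound 3 `O=C1C2CN(Cc3ccccc3)CC2CN1c1cccc2c1cnn2-c1ccccc1F` gives 2850 mL/min/kg in this assay.

Among these three numbers, compound 2 and compound 3 lie within the scatter of each other, so they cannot be ranked against one another. Within the data shown here, only compound 1 stands apart, and the single one-place step measured so far, a 2.9-fold lower number from compound 1 to compound 2 (0.46 log units; beyond the scatter), describes that gap.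

Compound 4 `O=C(COc1nn(-c2ccccc2F)c2ccc(F)cc12)N1CCOCC1` has not yet been measured. It differs from compound 2 in one place: (morpholin-4-yl)carbonyl in place of (2-oxo-1,3-oxazolidin-3-yl)methyl on a saturated chain carbon bound to an oxygen on an aromatic ring. Among the measured compounds shown here, no measured step follows this exchange. The step of a 2.9-fold lower number from compound 1 to compound 2 (0.46 log units; beyond the scatter) is the only one that alters the same chain, and it shows that a swap of the ring on that chain can shift the number by a modest amount. For the measured compounds named here, it does not say in which direction a morpholin-4-yl carbonyl would move it, since no compound carrying that group has a value here. The safest expectation is that compound 4 stays close to compound 2, with the expected step of a 1.0-fold higher number from compound 2 to compound 4 (0.00 log units; within the scatter) remaining within the scatter. Compound 4 is therefore estimated at 2500 mL/min/kg, with a range from 1000 mL/min/kg to 6000 mL/min/kg.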

Compound 4, clearance: 183 mL/min/kg
Compound 4: middle estimate off by 14-fold (1.14 log units), on the high side; the whole stated range lies above it.
By their numbers in this assay, from the lowest: compound 4; then compounds 2 and 3 (each within the scatter of the next); then compound 1.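

In this assay, among these compounds, the only earlier step on this chain was modest, but (morpholin-4-yl)carbonyl brings a far larger drop: a 14-fold lower number from compound 2 to compound 4 (1.13 log units; beyond the scatter), and a 39-fold lower number from compound 1 to compound 4 (1.59 log units; beyond the scatter). This saturated chain carbon bound to an oxygen on an aromatic ring is therefore a much more sensitive place than the first pair suggested, and the drop appears from both ring-bearing starting groups, not just one. The entering and leaving groups have the same counts of hydrogen-bond donors and acceptors, yet the exchange changes both the ring, from five-membered to six-membered, and the way that ring is attached to the chain, and no supporting measurement is available to explain the size of the drop.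

The compounds shown cannot separate the contribution of the morpholine ring from that of the amide carbonyl joined to the chain, a question that a 2-(morpholin-4-yl)ethyl group and a (piperidin-1-yl)carbonyl group would each address from a different side. They also leave open whether the ring is needed at all, as a simple dimethylamide at this place would show.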